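Nitro in place of chloro: expectation for compound 3

This account rests on a few compounds, and the source may have more. Where it says the series, first, only, none or still open, it means among the compounds named here.

Measured so far:
compound 1 `O=C(CN1CCC(c2cccc[n+]2[O-])CC1)Nc1ccc(F)cc1` — 71%
compound 2 `Cc1ccc(Cl)cc1NC(=O)CN1CCC(c2cccc[n+]2[O-])CC1` — 58%

In a functional assay on HEK293 cells for agonist activity at D(4) dopamine receptor (Homo sapiens), read by FLIPR (on this read-out lower numbers stand for smaller maximal responses and higher numbers for larger maximal responses), compound 1 gives 71% and compound 2 gives 58%. Within the data shown here, compound 2 thus stands lowest of the two measured numbers, the only neighbour being compound 1. Among the measured compounds shown here, the single measured step, a number 13 percentage points lower from compound 1 to compound 2 (beyond the scatter), comes from 5-chloro-2-methylphenyl in place of 4-fluorophenyl on an amide-type nitrogen, a change of the whole aryl group rather than of one substituent.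

Compound 3 `Cc1ccc([N+](=O)[O-])cc1NC(=O)CN1CCC(c2cccc[n+]2[O-])CC1` differs from compound 2 by nitro in place of chloro on an aromatic carbon. The change sits on an aromatic carbon of a six-membered aromatic ring of carbon only, meta to a large group and para to a methyl group. For the measured compounds named here, no measured step exchanges one substituent for another on this ring, so the step from compound 1 to compound 2 bears on it only indirectly: it shows that altering this ring moves the maximal response by a modest amount. A step of similar or smaller size, in either direction, is therefore expected, most likely within the scatter.

For compound 3 the maximal response in this assay is estimated at 55%, with a range from 40% to 70%. This corresponds to an expected step of a number 3 percentage points lower from compound 2 to compound 3 (within the scatter).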

Compound 3, largest response reached (reported as efficacy), in percent of the reference or control that the assay uses: 76%
Compound 3: the middle estimate sits 21 percentage points below what was measured; the whole stated range lies below it.
By their numbers in this assay, from the lowest: compound 2; then compounds 1 and 3 (each within the scatter of the next).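

Nitro in place of chloro, on the aromatic carbon para to a methyl group, gives in this assay a number 18 percentage points higher from compound 2 to compound 3 (beyond the scatter); this is the first step in the series that exchanges one substituent on this ring while the rest of the structure stays fixed, and it shows that this position alone can shift the maximal response. The methyl group is common to both compounds, so the presence of that group does not by itself hold the response down: compound 3 keeps it and gives 76%, within the scatter of compound 1 at 71%. Nothing shown here explains why the nitro and chloro compounds differ in this way.

Going by these compounds, whether the response at this carbon depends on the particular substituent in a wider sense stays open, since only chloro and nitro are compared there, and an amine, a nitrile or a carboxylic acid on the same carbon would test this further. The part played by the methyl group also stays open, as no pair shown differs at that group alone.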